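Heteroaryl exchange in a small growth-inhibition series

A few compounds are considered here, and "the series" means these few. Any claim that something is new, unique, unknown or untested is made for them only; others in the source may bear on it.

compound 1 `COc1cc(CSc2cc(Cl)c(-c3nnc(-c4ccc(Cl)cc4)s3)cc2S(=O)(=O)NC(=N)NO)cc(OC)c1OC` — 44700 nM
compound 2 `N=C(NO)NS(=O)(=O)c1cc(-c2nnc(-c3ccc(Cl)cc3)s2)c(Cl)cc1SCc1ccccc1` — 1990 nM

In a functional assay on UO-31 cells (Homo sapiens) (on this read-out lower numbers stand for stronger inhibition of growth and higher numbers for weaker inhibition of growth), compound 1 gives 44700 nM, the highest of the two numbers; its nearest neighbour is compound 2, reached by a 22-fold lower number from compound 1 to compound 2 (1.35 log units; beyond the scatter). Compound 3 `COc1cc(CSc2cc(Cl)c(-c3nc(-c4ccccc4)no3)cc2S(=O)(=O)NC(=N)NO)cc(OC)c1OC` differs from compound 1 by 3-phenyl-1,2,4-oxadiazol-5-yl in place of 5-(4-chlorophenyl)-1,3,4-thiadiazol-2-yl on an aromatic carbon. Going by the values given here, the single measured step alters a different part of the shared core, so no measured step bears on this heteroaryl exchange and the direction is unknown. With nothing to lean on, the expected change in this assay is a 1.0-fold higher number from compound 1 to compound 3 (0.00 log units; within the scatter), with a wide range. Compound 3 is estimated at 45000 nM, between 10000 nM and 150000 nM.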

Compound 3, concentration for 50% growth inhibition: 4470 nM
For compound 3 the middle estimate is 10-fold (1.00 log units) above the measured one, outside the stated range (below it).
By their numbers in this assay, from the lowest: compound 2; then compound 3; then compound 1.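

In this assay, 3-phenyl-1,2,4-oxadiazol-5-yl in place of 5-(4-chlorophenyl)-1,3,4-thiadiazol-2-yl gives a 10-fold lower number from compound 1 to compound 3 (1.00 log units; beyond the scatter). This aromatic carbon, ortho to a chloro group, is therefore a place where a single exchange moves the number beyond the scatter. Nothing available explains this step.

The exchange alters the five-membered ring and removes the chlorine of the aryl group together, so their contributions remain unseparated. A 3-(4-chlorophenyl)-1,2,4-oxadiazol-5-yl group at this carbon would separate them.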